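A Third Nitro Placement on a Weakly Active Core

This account rests on a few compounds, and the source may have more. Where it says the series, first, only, none or still open, it means among the compounds named here.

Compound 1 `Nn1c(SCc2ccccc2)nnc1-c1c[nH]c2ccccc12` was tested in a functional assay on Jurkat cells (Homo sapiens) for cytotoxicity, with a stated time of 24 h; a higher number here means a weaker inhibitor, a lower number a stronger inhibitor. In this assay compound 1 gives > 100000 nM, which is a limit of the assay and not a measured number. Compound 2 `Nn1c(SCc2ccccc2[N+](=O)[O-])nnc1-c1c[nH]c2ccccc12` carries a nitro group in place of a hydrogen on an aromatic carbon, and in this assay compound 2 gives > 100000 nM, again a limit. Compound 3 `Nn1c(SCc2cccc([N+](=O)[O-])c2)nnc1-c1c[nH]c2ccccc12` carries the nitro group on another aromatic carbon, and in this assay compound 3 gives > 100000 nM, also a limit. Because all three values sit at the same limit (the limit of > 100000 nM in this assay, at which 3 of the 3 values shown sit), neither the step that the two limits leave unreadable from compound 1 to compound 2 nor the step that the two limits leave unreadable from compound 1 to compound 3 can be read in size or direction; nothing in these numbers shows whether adding a nitro group helps, hurts or does nothing.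

Compound 4 `Nn1c(SCc2ccc([N+](=O)[O-])cc2)nnc1-c1c[nH]c2ccccc12` differs from compound 1 by nitro in place of hydrogen on an aromatic carbon. The two measured steps are the only ones that bear on this change, and both are unreadable. Compound 4 is therefore expected to behave like its relatives and to return only a limit, with an estimated value of 200000 nM (range 100000 nM to 1000000 nM). The expected step that the limit leaves unreadable from compound 1 to compound 4 is thus no readable change, in line with what the other nitro placements showed.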

Compound 4, half-maximal inhibitory concentration: > 100000 nM
Compound 4 ended at the assay's limit (the forecaster's own chance of this, stated with the estimate: 90%); the middle value does not contradict the limit.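

In this assay compound 4 gives > 100000 nM as a limit of the assay and not a number. The step from compound 1 to compound 4, like the steps to compound 2 and compound 3, cannot be read in size or direction, because every value sits at one limit: the limit of > 100000 nM in this assay, at which 4 of the 4 values shown sit.

The compounds shown leave open whether in this assay any of the three nitro placements truly differs from compound 1 at all.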